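Changing the phenyl group on the ring nitrogen

The compounds below may be only part of what the source reports. "The series", "measured", "known", "first", "only" and "open" are said of these compounds alone.

Of the compounds shown here, three sharing one core have been tested in a functional assay on A549 cells (Homo sapiens) for antiproliferative activity, read by MTT assay, with a stated time of 48 h; on this read-out higher numbers stand for weaker inhibition and lower numbers for stronger inhibition. Compound 1, `Cc1ccc(Cl)cc1-n1nncc1CN1C(=O)C2(C(C#N)=C(N)Oc3c2c2nc4ccccc4nc2c2ccccc32)c2ccccc21`, reaches only the limit of the assay, giving > 50000 nM, a limit rather than a number (the limit of > 50000 nM in this assay, at which 1 of the 3 values shown sits). Compound 2, `Cc1cccc(-n2nncc2CN2C(=O)C3(C(C#N)=C(N)Oc4c(N)cc5nc6ccccc6nc5c43)c3ccccc32)c1`, gives 12300 nM. Compound 3, `N#CC1=C(N)Oc2c(N)cc3nc4ccccc4nc3c2C12C(=O)N(Cc1cnnn1-c1cccc(Br)c1)c1ccccc12`, gives 18900 nM, the higher of the two numbers; the gap to compound 2 lies within the scatter, so the two cannot be ordered. Among the compounds with values here, the single step between them, a 1.5-fold higher number from compound 2 to compound 3 (0.19 log units; within the scatter), shows that exchanging one small substituent on the phenyl group left the read-out essentially unchanged.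

Compound 4, `CCOc1ccc(-n2nncc2CN2C(=O)C3(C(C#N)=C(N)Oc4c(N)cc5nc6ccccc6nc5c43)c3ccccc32)cc1`, is not yet measured. It differs from compound 3 in one place: 4-ethoxyphenyl in place of 3-bromophenyl on an aromatic nitrogen. Within the data shown here, the only measured step that touches this phenyl group is the one from compound 2 to compound 3, and it stayed within the scatter. Among the measured compounds shown here, nothing among the measured compounds speaks for a larger effect of a different substituent on this ring, so for compound 4 the expected step is a 1.2-fold lower number from compound 3 to compound 4 (0.07 log units; within the scatter), no change beyond the scatter. Compound 4 is therefore estimated to give 16000 nM in this assay, with a range from 5000 nM to 45000 nM.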

Compound 4, half-maximal inhibitory concentration: > 50000 nM
Compound 4 was reported as a limit; the forecaster's own chance of this, stated with the estimate: 15%; middle value at least 3.1-fold (0.49 log units) away from the limit.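

The phenyl group on the aromatic nitrogen is less indifferent than the earlier step, a 1.5-fold higher number from compound 2 to compound 3 (0.19 log units; within the scatter), suggested: in this assay, 4-ethoxyphenyl in place of 3-bromophenyl gives an at least 2.6-fold higher number from compound 3 to compound 4 (0.42 log units; beyond the scatter), and 4-ethoxyphenyl in place of 3-methylphenyl gives an at least 4.0-fold higher number from compound 2 to compound 4 (0.60 log units; beyond the scatter). Both steps lie beyond the scatter, so on this core a change on this phenyl group alone can weaken the read-out, which the bromo and methyl pair could not show. Compound 4 gives > 50000 nM, which is a limit and not a number, so both steps have a known minimum but no known full size: the limit of > 50000 nM in this assay, at which 2 of the 4 values shown sit.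

The change from 3-bromophenyl or 3-methylphenyl to 4-ethoxyphenyl alters both the group and its place on the ring at once, so the compounds shown cannot separate the ethoxy group from its place. On these data alone, it also remains open how a smaller methoxy group, an amine or a longer alkoxy chain on this phenyl ring would read out, and whether any group here could give stronger inhibition than compound 2 or compound 3.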